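This account rests on a few compounds, and the source may have more. Where it says the series, first, only, none or still open, it means among the compounds named here.

Of the compounds shown here, three on one shared core have been measured in an ADME assay on a cell-free system (plasma, Homo sapiens) (a higher number here means a larger unbound share of the compound, a lower number a smaller unbound share), and there compound 1 `CCNC(=O)Nc1nc2cc(-c3cncnc3)c(=O)n(C(C)C)c2s1` gives 0.15 while compound 2 `CCNC(=O)Nc1nc2cc(-c3cncc(F)c3)c(=O)n(C(C)C)c2s1` gives 0.1 and compound 3 `CCNC(=O)Nc1nc2cc(-c3cncc(OC)c3)c(=O)n(C(C)C)c2s1` gives 0.08 as its reading. Compound 3 stands within the scatter of both others, with a 1.9-fold lower number from compound 1 to compound 3 (0.27 log units; within the scatter) and a 1.3-fold lower number from compound 2 to compound 3 (0.10 log units; within the scatter) as its steps. The change to compound 4 `CCNC(=O)Nc1nc2cc(-c3ccc(C#N)nc3)c(=O)n(C(C)C)c2s1` is 6-cyanopyridin-3-yl in place of 5-methoxypyridin-3-yl on an aromatic carbon and amounts to 6-cyanopyridin-3-yl in place of 5-methoxypyridin-3-yl on an aromatic carbon. Within the data shown here, no measured step makes this exact exchange. The steps at that place, namely a 1.5-fold lower number from compound 1 to compound 2 (0.18 log units; within the scatter) and the two just given, all stay within the scatter, so no step beyond it is expected in this assay for compound 4. The expected step is a 1.3-fold higher number from compound 3 to compound 4 (0.10 log units; within the scatter) on this estimate. Compound 4 is therefore estimated at 0.1 with a range of 0.05 to 0.2 expected around it.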

Compound 4, unbound fraction: 0.04
Compound 4: the middle estimate sits 2.5-fold (0.40 log units) above what was measured, and the stated range ends above it.
By their numbers in this assay, from the lowest: compounds 4, 3, 2 and 1 (each within the scatter of the next, the first and the last beyond it).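

In this assay, among these compounds, 6-cyanopyridin-3-yl gives the first steps at this aromatic carbon that pass beyond the scatter (a 2.5-fold lower number from compound 2 to compound 4 (0.40 log units; beyond the scatter) and a 3.8-fold lower number from compound 1 to compound 4 (0.57 log units; beyond the scatter)), while the exchange for 5-methoxypyridin-3-yl stays inside it (a 2.0-fold lower number from compound 3 to compound 4 (0.30 log units; within the scatter)). Compound 4 thus stands apart from compound 1 and compound 2, but not from compound 3. Nothing at hand accounts for this. Still open, as far as these compounds go, is whether these steps belong to the nitrile or to the pyridine carrying it, and whether an amine or a carboxylic acid there would raise the unbound fraction.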